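The compounds below may be only part of what the source reports. "The series", "measured", "known", "first", "only" and "open" are said of these compounds alone.

Of the compounds shown here, two in this set have been measured in a functional assay on HCT-116 cells (Homo sapiens) for inhibition, read by sulforhodamine B assay, with a stated time of 3 days; a higher number here means a weaker inhibitor, a lower number a stronger inhibitor. Compound 1 `O=C1Nc2ccc(F)cc2/C1=C\C(=O)c1cnc2ccc(Cl)nn12` gives 1410 nM in this assay. Compound 2 `CN1CCN(c2cccc(N/C=C3\C(=O)Nc4ccc(NC(=O)c5cccc(F)c5)cc43)c2)CC1` gives 2740 nM in this assay, the higher of the two numbers shown, but its gap to compound 1 lies within the scatter of repeated measurements, so the two cannot be placed in order. Compound 3 `CC(C)CC(=O)Nc1ccc2c(c1)/C(=C/Nc1cccc(N3CCN(C)CC3)c1)C(=O)N2` has not yet been measured. It differs from compound 2 in one place: isobutyl in place of 3-fluorophenyl on a carbonyl carbon. Among the compounds with values here, no pair of measured compounds carries this change, so no measured step speaks directly to it. In this assay compound 3 is expected to show a step of a 1.3-fold higher number from compound 2 to compound 3 (0.11 log units; within the scatter), most likely a modest rise in the number that may not exceed the usual scatter. Within the data shown here, because compound 2 gives 2740 nM and no measured pair isolates this change, the expectation for compound 3 stays close to that value. Compound 3 is estimated to give 3500 nM in this assay, with a range from 1200 nM to 10000 nM.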

Compound 3, half-maximal inhibitory concentration: 9410 nM
Beside the measured number, compound 3's estimate is 2.7-fold (0.43 log units) below it; the range from low to high includes it.
By their numbers in this assay, from the lowest: compounds 1 and 2 (each within the scatter of the next); then compound 3.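

Within the data shown here, with the methylpiperazine-bearing remainder of the molecule held the same, placing isobutyl in place of 3-fluorophenyl on a carbonyl carbon whose other neighbour is an amide-type nitrogen gives a 3.4-fold higher number from compound 2 to compound 3 (0.54 log units; beyond the scatter) in this assay, the first step in this set that isolates a single change and lies beyond the scatter. It shows that the group at this position bears on the number in this assay, and that this exchange, which removes the six-membered aromatic ring of carbon only and replaces 7 heavy atoms with 4, goes with a weaker inhibitor while the counts of hydrogen-bond donors, acceptors and charge stay the same. Nothing shown here bears on the reason for this step.

On these data alone, it remains open whether the rise follows the loss of the fluorine, the loss of the aromatic ring or the smaller size of the group: a phenyl without the fluorine, a cyclohexyl or a longer chain on this carbonyl carbon would separate these readings. As far as these compounds go, whether the same exchange behaves alike on another core, such as that of compound 1, is also open.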